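The source may report more compounds than this note shows. Statements on the series, on what has been measured and on what is new or still open speak of the compounds shown alone.

Compound 1, `CCOC(=O)c1c(-c2cccc(C(F)(F)F)c2)csc1N`, in a functional assay on CHO-K1 cells for agonist activity at adenosine receptor A1 (Homo sapiens), read by GTPgammaS binding (a higher number here means that more compound is needed for the effect, a lower number that less compound is needed), compound 1 gives 9.4 uM.
Compound 2, `Nc1scc(-c2cccc(C(F)(F)F)c2)c1C(=O)c1ccccc1`, in this assay compound 2 gives 15.8 uM.

Within the data shown here, of these two numbers, compound 2 has the higher one, but the only measured step, a 1.7-fold higher number from compound 1 to compound 2 (0.23 log units; within the scatter), is small, and it concerns a phenyl in place of ethoxy on the carbonyl carbon. Compound 3, `CC(=O)c1cccc(-c2sc(N)c(C(=O)c3ccccc3)c2-c2cccc(C(F)(F)F)c2)c1`, not yet measured, differs from compound 2 at another place: 3-acetylphenyl in place of hydrogen on an aromatic carbon. Among the measured compounds shown here, no measured step touches this ring carbon, so nothing among the measured compounds tells how the number moves when a group of this size is added there; the one measured step, a 1.7-fold higher number from compound 1 to compound 2 (0.23 log units; within the scatter), offers no guide beyond showing that a change elsewhere on the core left the number within the scatter. The expectation for compound 3 therefore rests on compound 2 alone, with a wide range and no direction favoured: compound 3 is estimated at 15 uM, between 4 uM and 60 uM. This estimate means a 1.1-fold lower number from compound 2 to compound 3 (0.02 log units; within the scatter), a step expected to stay within the scatter.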

Compound 3, concentration for half-maximal effect: > 10 uM
Compound 3: a limit, no number; the forecaster's own chance of this, stated with the estimate: 20%; the middle value is on the limit's open side.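

In this assay compound 3 gives > 10 uM, which is a limit of the assay and not a number. The step from compound 2 to compound 3 therefore cannot be read. The compounds shown leave open how far, and in which direction, the number moves when 3-acetylphenyl replaces hydrogen on this ring carbon.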